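From Fluoro to Methoxy on a Shared Core

The compounds below may be only part of what the source reports. "The series", "measured", "known", "first", "only" and "open" are said of these compounds alone.

In a functional assay on OCI-Ly3 cells (Homo sapiens) for antiproliferative activity (on this read-out lower numbers stand for an effect already at smaller amounts and higher numbers for an effect only at larger amounts of compound), compound 1 `O=C(Nc1cnc(-n2nccn2)c(Cl)c1)Nc1cnc2ccccc2c1C1CC1` gives 1580 nM and compound 3 `O=C(Nc1cnc(-n2nccn2)c(Cl)c1)Nc1cnc2cc(F)ccc2c1C1CC1` gives 900 nM. Among the measured compounds shown here, these are the only two true numbers so far, and they cannot be told apart: the data show a 1.8-fold lower number from compound 1 to compound 3 (0.24 log units; within the scatter). Compound 2 `O=C(Nc1cnc(-n2nccn2)c(Cl)c1)Nc1cnc2cc(Cl)ccc2c1C1CC1` gives > 20000 nM, which is a limit of the assay and not a number.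

Compound 4 `COc1ccc2c(C3CC3)c(NC(=O)Nc3cnc(-n4nccn4)c(Cl)c3)cnc2c1` carries methoxy in place of fluoro on an aromatic carbon. Two measured changes on this same carbon bear on it. Chloro in place of hydrogen gave an at least 12-fold higher number from compound 1 to compound 2 (1.10 log units; beyond the scatter), and fluoro in place of chloro gave an at least 22-fold lower number from compound 2 to compound 3 (1.34 log units; beyond the scatter). Methoxy itself has not been measured on this core, so these steps guide the direction more than the size. A rise is expected, though a smaller one than the chloro steps, and the step expected is a 4.4-fold higher number from compound 3 to compound 4 (0.65 log units; beyond the scatter). The estimate for compound 4 is 4000 nM, with an expected range from 800 nM to 20000 nM.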

Compound 4, half-maximal effective concentration: > 20000 nM
Compound 4 ended at the assay's limit (the forecaster's own chance of this, stated with the estimate: 25%); middle value at least 5.0-fold (0.69 log units) from the limit.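

Among the compounds shown here, until now chloro was the only group on this aromatic carbon to reach the limit of this assay. Methoxy behaves the same way, with an at least 22-fold higher number from compound 3 to compound 4 (1.34 log units; beyond the scatter) and an at least 12-fold higher number from compound 1 to compound 4 (1.10 log units; beyond the scatter), so the large loss is not peculiar to chloro, and of the three groups placed here only fluoro stays within the scatter of hydrogen. The step from compound 2 to compound 4 cannot be read, and neither group can be ranked against the other, because both values are limits and not numbers: the limit of > 20000 nM in this assay, at which 2 of the 4 values shown sit.

The compounds shown leave open whether a methyl, a hydroxyl or an amine on this carbon would give a true number or also reach the limit. They also leave open whether methoxy would give the same result on another carbon of this ring.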